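A few compounds are considered here, and "the series" means these few. Any claim that something is new, unique, unknown or untested is made for them only; others in the source may bear on it.

Measured so far in a functional assay on A-375 cells (Homo sapiens) for activation, with a stated time of 3 days; on this read-out higher numbers stand for an effect only at larger amounts of compound and lower numbers for an effect already at smaller amounts
- compound 1 `O=C(Nc1ccc(-c2c[nH]cn2)cc1)C1CCCN(Cc2ccc(F)c(F)c2)C1` gives 16000 nM
- compound 2 `O=C(Nc1ccc(-c2ccco2)cc1)C1CCCN(Cc2ccc(F)c(F)c2)C1` gives 2200 nM

Compound 2 holds the lower of the two numbers. In compound 3 `O=C(Nc1ccc(-c2cc[nH]c2)cc1)C1CCCN(Cc2ccc(F)c(F)c2)C1`, 1H-pyrrol-3-yl replaces furan-2-yl on an aromatic carbon (1H-pyrrol-3-yl in place of furan-2-yl on an aromatic carbon). Among the measured compounds shown here, the only measured step at this place is modest (a 7.3-fold lower number from compound 1 to compound 2 (0.86 log units; beyond the scatter)), and it exchanges 1H-imidazol-4-yl for furan-2-yl. With this single step as a guide, a smaller move towards a higher number is expected in this assay. The estimated step stays small (a 1.8-fold higher number from compound 2 to compound 3 (0.26 log units; within the scatter)). For compound 3 the expected value is 4000 nM (estimated range 1200 nM to 13000 nM).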

Compound 3, half-maximal effective concentration: 2610 nM
Compound 3: middle estimate off by 1.5-fold (0.19 log units), on the high side; measured number inside the range.
By their numbers in this assay, from the lowest: compounds 2 and 3 (each within the scatter of the next); then compound 1.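

In this assay, exchanging furan-2-yl, with its hydrogen-bond acceptor, for 1H-pyrrol-3-yl, with its hydrogen-bond donor, stays within the scatter: a 1.2-fold higher number from compound 2 to compound 3 (0.07 log units; within the scatter). On this aromatic carbon, the two rings are therefore not told apart, while 1H-imidazol-4-yl remains separate from the new ring as well: a 6.1-fold lower number from compound 1 to compound 3 (0.79 log units; beyond the scatter). Nothing available explains this result.

Still open, going by these compounds, is whether a phenyl ring, a pyridine ring or a carboxylic acid at this place would match compound 2 and compound 3 or move the number beyond the scatter.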